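Trimming a thiazole to a methyl: cytotoxicity expected unchanged

The source may report more compounds than this note shows. Statements on the series, on what has been measured and on what is new or still open speak of the compounds shown alone.

Compound 1 `Cc1nc(C)c(Cn2ncc3c(Nc4ccc(OC(F)(F)F)cc4)ncnc32)s1`: in an ADME assay on BaF3 cells (Mus musculus) for cytotoxicity (on this read-out lower numbers stand for an effect already at smaller amounts and higher numbers for an effect only at larger amounts of compound), compound 1 gives > 10000 nM, which is a limit of the assay.
Compound 2 `CCCn1cc2c(Nc3ccc(OC(F)(F)F)cc3)ncnc2n1`: compound 2 gives > 10000 nM, also a limit.
Compound 3 `FC(F)(F)c1ccc(Nc2cc(-c3ccncc3)ncn2)cc1`: compound 3 gives > 10000 nM, again a limit.

Compound 1 therefore has no number of its own in this assay, only (the limit of > 10000 nM in this assay, at which 3 of the 3 values shown sit). Nothing among the three measured compounds separates one from another; none shows an effect within the tested range.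

Compound 4 `CCn1ncc2c(Nc3ccc(OC(F)(F)F)cc3)ncnc21` is the next compound to be tested. Its change from compound 1 is methyl in place of 2,4-dimethyl-1,3-thiazol-5-yl on a saturated chain carbon bound to an aromatic nitrogen; cut one bond further out, the same difference reads as (2,4-dimethyl-1,3-thiazol-5-yl)methyl to ethyl. For the measured compounds named here, no measured pair of compounds differing in one place is available, so the size of this step rests on the shared picture alone: all three measured compounds sit at the limit.

The expected step of a number no higher from compound 1 to compound 4 (the limit leaves the size open) is none beyond the scatter. Compound 4 is thus estimated at 10000 nM, within 5000 nM to 30000 nM, most likely reported as a limit once more.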

Compound 4, half-maximal effective concentration: > 10000 nM
Compound 4: a limit, no number; the forecaster's own chance of this, stated with the estimate: 85%; the middle value sits exactly at the limit.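

In this assay, for the compounds shown here, compound 1 and compound 4 both stop at a limit and give no number, so no step between them can be read: the limit of > 10000 nM in this assay, at which 4 of the 4 values shown sit.

Still open, on these data alone, is how large the effect of swapping 2,4-dimethyl-1,3-thiazol-5-yl for methyl is, and at what concentration, if any, these compounds show cytotoxicity.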